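The source may hold more compounds than are shown below. What is called first, only, known or untested is meant among the compounds shown, and "the series" means these compounds.

Measured compounds in a functional assay on HL-60 cells (Homo sapiens) for cytotoxicity, read by WST assay, with a stated time of 48 h; on this read-out higher numbers stand for weaker inhibition and lower numbers for stronger inhibition:
- compound 1 `O[C@@H](c1ccccc1)[C@H]1CO[C@H](c2ccccc2)[C@@H](C/C=C/c2ccncc2)C1`: > 100000 nM
- compound 2 `O[C@@H](c1ccccc1)[C@H]1CO[C@H](c2ccccc2)[C@@H](C/C=C/C2CCCCC2)C1`: 6260 nM
- compound 3 `COc1ccc(/C=C/C[C@@H]2C[C@H]([C@H](O)c3ccc(OC)c(OC)c3)CO[C@H]2c2ccc(OC)c(OC)c2)cc1OC`: "not determined" (no result reported)

Compound 1 stands only at a limit in this assay: its value of > 100000 nM is the upper limit of the measurement, not a number, and it is the one entry sitting at the limit of > 100000 nM in this assay, at which 1 of the 3 values shown sits. Compound 2 gives 6260 nM in this assay. For compound 3 no result was reported in this assay.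

Among the compounds with values here, the single measured step that bears on the present question is an at least 15-fold lower number from compound 1 to compound 2 (1.20 log units; beyond the scatter), a large step beyond the scatter from the limit down to a measured number. Compound 4 `CCCCCC/C=C/C[C@H]1C[C@@H]([C@@H](O)c2ccccc2)CO[C@@H]1c1ccccc1` differs from compound 1 in the same place, by hexyl in place of pyridin-4-yl on a double-bonded chain carbon bound to a double-bonded chain carbon. As in the move to compound 2, the pyridin-4-yl is exchanged for a group with no hetero atom and no hydrogen-bond acceptor, here a hexyl rather than a cyclohexyl. A step of the same direction and roughly the same size is therefore expected, an at least 12-fold lower number from compound 1 to compound 4 (1.09 log units; beyond the scatter), bringing compound 4 off the limit and into the region of compound 2. The estimate for compound 4 in this assay is 8000 nM, expected to fall between 2000 nM and 40000 nM, with some chance that only a limit is again reported.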

Compound 4, half-maximal inhibitory concentration: 4990 nM
Compound 4: middle estimate off by 1.6-fold (0.20 log units), on the high side; low and high end bracket the measured number.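

Compound 1 in this assay remains a limit and not a number: the limit of > 100000 nM in this assay, at which 1 of the 4 values shown sits.

With hexyl in place of pyridin-4-yl on a double-bonded chain carbon bound to a double-bonded chain carbon, there is an at least 20-fold lower number from compound 1 to compound 4 (1.30 log units; beyond the scatter), so leaving the limit is not tied to the cyclohexyl ring of compound 2 and also occurs with an open chain. Comparing the two carbon groups gives a 1.3-fold lower number from compound 2 to compound 4 (0.10 log units; within the scatter), so in this assay the cyclohexyl and hexyl groups cannot be told apart at this place, and among the compounds with a number, the presence or absence of a ring in this group makes no readable difference.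

As far as these compounds go, whether pyridin-4-yl stands apart through its nitrogen or through its aromatic ring remains open, and phenyl at this place would separate the two. Also open, from the compounds shown here alone, is how the number follows chain length, from butyl to a longer chain such as decyl, and what a chain carrying an amine would give.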